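Replacing the Piperidinyl Group with a Carboxypyridinyl Ring

A few compounds are considered here, and "the series" means these few. Any claim that something is new, unique, unknown or untested is made for them only; others in the source may bear on it.

Of the compounds shown here, two sharing one core have been measured in an in vitro assay on CHO cells for displacement of a labelled ligand from Bombesin receptor subtype-3 (Homo sapiens), read by scintillation counting, with a stated time of 2 h; on this read-out lower numbers stand for stronger inhibition and higher numbers for weaker inhibition. Compound 1 `CCC(C)(C)Cc1c[nH]c(CCc2ccc(-n3ncnn3)cc2)n1` gives 205 nM. Among the compounds with values here, compound 2 `CCC(C)(C)Cc1c[nH]c(CCc2ccc(N3CCCCC3)cc2)n1` gives 28 nM, which is the lowest of the two numbers; its only measured neighbour lies at a 7.3-fold lower number from compound 1 to compound 2 (0.86 log units; beyond the scatter). Compound 3 `CCC(C)(C)Cc1c[nH]c(CCc2ccc(-c3cccnc3C(=O)O)cc2)n1` has not yet been measured. It differs from compound 2 in one place: 2-carboxypyridin-3-yl in place of piperidin-1-yl on an aromatic carbon. Within the data shown here, the only measured step that bears on this change is a 7.3-fold lower number from compound 1 to compound 2 (0.86 log units; beyond the scatter), in which 2H-tetrazol-2-yl on the same aromatic carbon was exchanged for piperidin-1-yl and the number fell. The change to compound 3 removes that piperidin-1-yl again and installs 2-carboxypyridin-3-yl, a six-membered aromatic ring, so the step is expected to run the other way, towards a higher number beyond the scatter and of roughly the size of the earlier step, although nothing measured shows how a 2-carboxypyridin-3-yl group itself behaves on this core. Compound 3 is therefore expected to give 350 nM, between 90 nM and 1500 nM. This corresponds to an expected step of a 13-fold higher number from compound 2 to compound 3 (1.10 log units; beyond the scatter).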

Compound 3, half-maximal inhibitory concentration: 560 nM
Beside the measured number, compound 3's estimate is 1.6-fold (0.20 log units) below it; measured number inside the range.
By their numbers in this assay, from the lowest: compound 2; then compound 1; then compound 3.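

In this assay, the aromatic carbon para to a large group proves sensitive to a second aromatic ring group: 2-carboxypyridin-3-yl in place of piperidin-1-yl gives a 20-fold higher number from compound 2 to compound 3 (1.30 log units; beyond the scatter), a large step. The same group also ranks behind 2H-tetrazol-2-yl, with a 2.7-fold higher number from compound 1 to compound 3 (0.44 log units; beyond the scatter), so across these three compounds the lowest number belongs to the only one carrying a six-membered non-aromatic ring, and neither of the other two goes against this, although three compounds support no wider rule. Nothing available accounts for the rise in the number.

The change from compound 2 to compound 3 alters the ring and adds a carboxylic acid in one move, so the compounds shown leave open which of the two goes with the higher number; a plain pyridin-3-yl ring or the methyl ester of the acid would bear on that. They also leave open whether other amines on this carbon, such as morpholin-4-yl or an open-chain dimethylamino group, would stay close to compound 2.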